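Fluoro for trifluoromethyl carried onto a second core

The compounds below may be only part of what the source reports. "The series", "measured", "known", "first", "only" and "open" are said of these compounds alone.

Compound 1 `O=C1/C(=C/c2cccc(F)c2)CN(S(=O)(=O)c2ccc(C(F)(F)F)cc2)C/C1=C\c1cccc(F)c1` and compound 2 `O=C1/C(=C/c2cccc(F)c2)CN(S(=O)(=O)c2ccc(F)cc2)C/C1=C\c1cccc(F)c1` share one core and differ only by fluoro in place of trifluoromethyl on an aromatic carbon. In a functional assay on HepG2 cells (Homo sapiens) for cytotoxicity, read by MTT assay, with a stated time of 24 h (on this read-out higher numbers stand for weaker inhibition and lower numbers for stronger inhibition), compound 1 gives 2400 nM and compound 2 gives 5000 nM, and the step between them is a 2.1-fold higher number from compound 1 to compound 2 (0.32 log units; beyond the scatter). Compound 3 `O=C1/C(=C/c2ccc(F)cc2)CN(S(=O)(=O)c2ccc(C(F)(F)F)cc2)C/C1=C\c1ccc(F)cc1` carries the trifluoromethyl group on a second core; how the core of compound 3 differs from the core of compound 1 is not broken down here. In this assay compound 3 gives 3200 nM, which lies within the scatter of the number for compound 1 and also within the scatter of the number for compound 2, so no order among these three is claimed beyond the step from compound 1 to compound 2.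

Compound 4 `O=C1/C(=C/c2ccc(F)cc2)CN(S(=O)(=O)c2ccc(F)cc2)C/C1=C\c1ccc(F)cc1` has not yet been measured. It differs from compound 3 by fluoro in place of trifluoromethyl on an aromatic carbon. For the measured compounds named here, the place is described in the same words for both pairs, so this is the same change as the one from compound 1 to compound 2, now made on the core of compound 3. Going by the values given here, nothing measured tells whether the second core carries the change in the same way; the single earlier step is the only guide. Among the compounds with values here, compound 4 is therefore expected to show a 2.0-fold higher number from compound 3 to compound 4 (0.31 log units; beyond the scatter) in this assay, matching the earlier step, because the only measured instance of this change is a 2.1-fold higher number from compound 1 to compound 2 (0.32 log units; beyond the scatter). Compound 4 is estimated at 6500 nM, with a range from 3300 nM to 13000 nM, kept wide since the expectation rests on one pair only.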

Compound 4, half-maximal inhibitory concentration: 8100 nM
Compound 4: the middle estimate sits 1.2-fold (0.10 log units) below what was measured; the measured number falls inside the stated range.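

On the core of compound 3, replacing 4-(trifluoromethyl)phenyl with 4-fluorophenyl gives a 2.5-fold higher number from compound 3 to compound 4 (0.40 log units; beyond the scatter) in this assay, a shift towards weaker inhibition. The step on the core of compound 1 runs the same way, and the two steps do not separate in size: the same change on two cores in this assay, a 2.1-fold higher number (0.32 log units; beyond the scatter) from compound 1 to compound 2 and a 2.5-fold higher number (0.40 log units; beyond the scatter) from compound 3 to compound 4, 1.2-fold (0.08 log units) apart, within the scatter of two such steps Within these four compounds, the change therefore carries from one core to the other with its direction kept and no measurable change in size, but two pairs in a single assay set no rule for any further core or any other cell line, and they give no reason for the shift.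

On these data alone, both pairs test only trifluoromethyl against fluoro, so it remains open how an amine, a nitrile, a carboxylic acid or a methoxy group on the same aromatic carbon would compare on either core. Also open, as far as these compounds go, is whether the same change, made on the aromatic rings carried by the two carbon-carbon double bonds rather than on the ring attached to the sulfonyl group, would keep its direction from core to core.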